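The source may hold more compounds than are shown below. What is called first, only, known or untested is meant among the compounds shown, and "the series" means these compounds.

Compound 1 `CCCNc1nc(-c2ccccc2)nc2c1nnn2Cc1ccccc1`: 37 nM
Compound 2 `CCCCNc1nc(-c2ccccc2)nc2c1nnn2Cc1ccccc1`: 11 nM
Compound 3 `OCCNc1nc(-c2ccccc2)nc2c1nnn2Cc1ccccc1Cl`: 116 nM

Of the compounds shown here, three have been measured in an assay on Cerebral cortex for displacement of a labelled ligand from adenosine receptor A1 (Bos taurus); on this read-out higher numbers stand for weaker inhibition and lower numbers for stronger inhibition. Compound 1 and compound 2 share a core and differ by methyl in place of hydrogen on a saturated chain carbon, three bonds along the chain from a nitrogen on an aromatic ring. This change gave a 3.4-fold lower number from compound 1 to compound 2 (0.53 log units; beyond the scatter). Compound 3 gives the highest number of the three in this assay; how its core differs from that of compound 1 is not broken down here.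

Compound 4 `CC(O)CNc1nc(-c2ccccc2)nc2c1nnn2Cc1ccccc1Cl` has not yet been measured. It differs from compound 3 by methyl in place of hydrogen on a saturated chain carbon bound to an oxygen on a saturated carbon and a saturated chain carbon. This is the same kind of change as that from compound 1 to compound 2, but the place is not the same: in the earlier pair the methyl enters on a saturated chain carbon three bonds along the chain from a nitrogen on an aromatic ring, whereas here it enters on a saturated chain carbon bound to an oxygen on a saturated carbon and a saturated chain carbon. Among the compounds with values here, only the one earlier step is available to rest on, and the changed surroundings argue for a more cautious expectation. Compound 4 is therefore expected to give 70 nM in this assay, between 30 nM and 200 nM, which corresponds to an estimated step of a 1.7-fold lower number from compound 3 to compound 4 (0.22 log units; within the scatter).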

Compound 4, inhibition constant: 32 nM
Compound 4: middle estimate off by 2.2-fold (0.34 log units), on the high side; low and high end bracket the measured number.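

In this assay, methyl in place of hydrogen turned the (2-hydroxyethyl)amino group into the (2-hydroxypropyl)amino group and gave a 3.6-fold lower number from compound 3 to compound 4 (0.56 log units; beyond the scatter). Set beside the earlier step on the other core, this step is of matching size: the same change on two cores in this assay, a 3.4-fold lower number (0.53 log units; beyond the scatter) from compound 1 to compound 2 and a 3.6-fold lower number (0.56 log units; beyond the scatter) from compound 3 to compound 4, 1.1-fold (0.03 log units) apart, within the scatter of two such steps. These two pairs therefore show the change carrying over between the two cores with its size intact, even though the methyl enters at a different place in each, but two pairs in a single assay do not make a rule for further cores or other chain positions, and they do not explain the match.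

The compounds shown leave open how a longer chain such as pentyl, or a chain ending in an amine or a carboxylic acid, would read in this assay. They also leave open whether a methoxy group in place of the hydroxyl of compound 4 would keep the step.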